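A few compounds are considered here, and "the series" means these few. Any claim that something is new, unique, unknown or untested is made for them only; others in the source may bear on it.

Measured compounds:
compound 1, `COc1cc(OCCOCCNC2CCCC2)ccc1OCc1ccccc1`, 44600 nM
compound 2, `COc1ccc(COc2ccc(OCCOCCNC3CCCC3)cc2)cc1`, 15700 nM
compound 3, `c1ccc(COc2ccc(OCCOCCNC3CCCC3)cc2)cc1`, 24800 nM

All three share one core and differ only in what sits on the outer benzene ring of the benzyl ether. In a functional assay on SK-OV-3 cells (Homo sapiens) for inhibition, read by CCK-8 assay, with a stated time of 70 h (on this read-out higher numbers stand for weaker inhibition and lower numbers for stronger inhibition), compound 1 gives 44600 nM, compound 2 gives 15700 nM and compound 3 gives 24800 nM. Compound 3 carries no substituent on that ring; its two neighbours in the numbers are compound 2 and compound 1, and both distances are small: a 1.6-fold higher number from compound 2 to compound 3 (0.20 log units; within the scatter), and a 1.8-fold lower number from compound 1 to compound 3 (0.25 log units; within the scatter). Neither step rises above the usual scatter, so the three compounds cannot be ranked against each other on this read-out.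

Compound 4, `O=[N+]([O-])c1ccc(COc2ccc(OCCOCCNC3CCCC3)cc2)cc1`, is the next step from compound 3. The change is nitro in place of hydrogen on an aromatic carbon. The two measured steps speak to it only loosely, since each swaps a methoxy for a hydrogen on an aromatic carbon of the same ring rather than a nitro, and both stayed within the scatter. On that basis no step beyond the scatter is expected in this assay; the estimated step is a 1.2-fold lower number from compound 3 to compound 4 (0.09 log units; within the scatter). The estimate for compound 4 is 20000 nM, with a range from 7000 nM to 60000 nM.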

Compound 4, half-maximal inhibitory concentration: 20300 nM
The estimate for compound 4 lay 1.0-fold (0.01 log units) below the measured number; the range from low to high includes it.
By their numbers in this assay, from the lowest: compounds 2, 4, 3 and 1 (each within the scatter of the next, the first and the last beyond it).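

Putting nitro in place of hydrogen on this aromatic carbon, para to a large group, gives a 1.2-fold lower number from compound 3 to compound 4 (0.09 log units; within the scatter) in this assay, and nitro in place of methoxy at the same carbon gives a 1.3-fold higher number from compound 2 to compound 4 (0.11 log units; within the scatter) on the same read-out. Until now this carbon had been seen with only hydrogen or methoxy; it now also carries nitro, a group of three heavy atoms, and none of the three compounds can be ranked against another. No measurement shown here gives any reason why these numbers stay so close.

As far as these compounds go, whether an amine, a carboxylic acid or a longer chain on this same carbon would move the number beyond the scatter stays open, as does whether nitro on another carbon of the same ring would do so. From the compounds shown here alone, the rest of the shared core is the same in compound 2, compound 3 and compound 4, so it also remains open whether a change elsewhere in that core would count for more than any change at this carbon.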